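The source may report more compounds than this note shows. Statements on the series, on what has been measured and on what is new or still open speak of the compounds shown alone.

Measured compounds:
compound 1, `COc1cc(Cl)cc(-c2nn(-c3cccc(NC(=O)Nc4cc(C(F)(F)F)cc(C(F)(F)F)c4)c3)cc2-c2ccncc2)c1`, -4.6%
compound 2, `COc1cc(Cl)cc(-c2nn(-c3cccc(NC(=O)c4cccc(C(F)(F)F)c4)c3)cc2-c2ccncc2)c1`, 34.1%
compound 3, `O=C(Nc1cccc(-n2cc(-c3ccncc3)c(-c3cc(O)cc(Cl)c3)n2)c1)c1cc(C(F)(F)F)cc(C(F)(F)F)c1`, 24.6%

In a functional assay on HCT-116 cells (Homo sapiens) for inhibition, read by sulforhodamine B assay, with a stated time of 48 h, tested at 10 uM (on this read-out higher numbers stand for a weaker effect at the one concentration tested and lower numbers for a stronger effect), compound 3 stands second highest of the three numbers. Its nearest neighbour is compound 2, whose number is higher but within the scatter, so no order between the two can be claimed; compound 1 lies well below it, beyond the scatter. Compound 4, `COc1cc(Cl)cc(-c2nn(-c3cccc(NC(=O)c4cc(C(F)(F)F)cc(C(F)(F)F)c4)c3)cc2-c2ccncc2)c1`, is not yet measured. It differs from compound 3 in one place: methyl in place of hydrogen on an oxygen on an aromatic ring. Among the compounds with values here, no pair of measured compounds differs by this change alone, so its effect is unknown here. Since compound 2, also carrying methoxy, gives 34.1%, a small step within the scatter in this assay is expected, if any. The expected step is a number 5.4 percentage points higher from compound 3 to compound 4 (within the scatter). For compound 4 an estimate of 30% is made, between 10% and 50%.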

Compound 4, a percentage reported as activity, at one concentration (the size of the read-out at that concentration, not a potency): 35.2%
Compound 4: the middle estimate sits 5.2 percentage points below what was measured; the range from low to high includes it.
By their numbers in this assay, from the lowest: compound 1; then compounds 3, 2 and 4 (each within the scatter of the next, the first and the last beyond it).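

In this assay, within the data shown here, the change from hydroxy to methoxy on the aromatic ring gives a number 10.6 percentage points higher from compound 3 to compound 4 (beyond the scatter) and so a weaker effect, the first reading of this change at this position. Trifluoromethyl in place of hydrogen on an aromatic carbon gives a number 1.1 percentage points higher from compound 2 to compound 4 (within the scatter) and so no readable change. Nothing measured here accounts for the hydroxy to methoxy step.

From the compounds shown here alone, whether ethoxy or an amine at this position would give a different number stays open. Among these compounds, this change has also been read in only one pair, so its effect in other compounds is unknown.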